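From chloro to fluoro at the half-life limit

The compounds below may be only part of what the source reports. "The series", "measured", "known", "first", "only" and "open" are said of these compounds alone.

Compound 1 `CC[C@@H]1NC(=O)[C@H](CCCNC(=N)N)NC(=O)[C@](C)(NC(=O)C(C)C)CCCCN(C)C(=O)[C@@H](c2ccc(Cl)cc2)NC1=O`: > 1 h
Compound 2 `CC[C@@H]1NC(=O)[C@H](CCCNC(=N)N)NC(=O)[C@](C)(NC(=O)C(C)C)CCCCNC(=O)[C@@H](c2ccccc2)NC1=O`: > 1 h
Compound 3 `CC[C@@H]1NC(=O)[C@H](CCCNC(=N)N)NC(=O)[C@](C)(NC(=O)C(C)C)CCCNC(=O)[C@@H](c2ccccc2)NC1=O`: > 1 h

In an ADME assay on microsomes (Rattus norvegicus) for metabolic stability (a lower number here means that the compound disappears faster, a higher number that the compound lasts longer), compound 1 gives > 1 h as a limit of the assay, not as a number. All three measured compounds stand together at the limit of > 1 h in this assay, at which 3 of the 3 values shown sit, so compound 1 has no exact position among them.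

Compound 4 `CC[C@@H]1NC(=O)[C@H](CCCNC(=N)N)NC(=O)[C@](C)(NC(=O)C(C)C)CCCCN(C)C(=O)[C@@H](c2ccc(F)cc2)NC1=O` keeps the core of compound 1 and differs in one place, with fluoro in place of chloro on an aromatic carbon, para to a large group (fluoro in place of chloro on an aromatic carbon). Among the measured compounds shown here, no measured pair shows this kind of change, so the data give no size for it. For the measured compounds named here, the only anchor is compound 1 with > 1 h as its reading, and that reading is a limit. In this assay no step beyond the scatter is expected in either direction, and the estimated step is a step that the limit leaves unreadable from compound 1 to compound 4. For compound 4 the expected half-life is 1.5 h, within an estimated range from 0.8 h to 4 h, though the assay may well report only a limit again.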

Compound 4, half-life: > 1 h
Compound 4: a limit, no number (the forecaster's own chance of this, stated with the estimate: 75%); the middle value does not contradict the limit.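

In this assay, among the compounds shown here, compound 4 gives > 1 h, a limit and not a number; compound 1 also stands at a limit, so no step between compound 1 and compound 4 can be read. The compounds shown leave open what half-life each actually has, and whether fluoro in place of chloro changes it.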